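The source may hold more compounds than are shown below. What is called first, only, known or untested is meant among the compounds shown, and "the series" means these compounds.

In a functional assay on NCI-H460 cells (Homo sapiens) for inhibition, read by CCK-8 assay, with a stated time of 72 h (a lower number here means a stronger inhibitor, a higher number a weaker inhibitor), compound 1 (`Nc1ccccc1NC(=O)c1ccc(CNC(=O)c2n[nH]cc2NC(=O)c2c(F)cccc2Cl)cc1`) gives 3630 nM, compound 2 (`Nc1ccccc1NC(=O)c1ccc(CNC(=O)c2n[nH]cc2NC(=O)c2ccccc2Cl)cc1`) gives 6360 nM and compound 3 (`COc1ccccc1C(=O)Nc1c[nH]nc1C(=O)NCc1ccc(C(=O)Nc2ccccc2N)cc1`) gives 7350 nM. Compound 2 cannot be told apart from either of the others: a 1.8-fold higher number from compound 1 to compound 2 (0.24 log units; within the scatter) and a 1.2-fold higher number from compound 2 to compound 3 (0.06 log units; within the scatter) both lie within the scatter. Only a 2.0-fold higher number from compound 1 to compound 3 (0.31 log units; beyond the scatter) goes beyond it, and modestly. All three carry the 2-aminophenyl group and differ elsewhere.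

Compound 4 (`O=C(NO)c1ccc(CNC(=O)c2n[nH]cc2NC(=O)c2ccccc2Cl)cc1`) keeps the rest of compound 2 but has hydroxy in place of 2-aminophenyl on an amide-type nitrogen. Going by the values given here, no measured compound changes at this place, so the steps bear on it only indirectly. Even a 2.0-fold higher number from compound 1 to compound 3 (0.31 log units; beyond the scatter) reflects a change made elsewhere and does not set the size of this one. The direction is therefore a tentative expectation, not a measured trend, and the range must stay wide. In this assay the expected change is a 4.2-fold lower number from compound 2 to compound 4 (0.63 log units; beyond the scatter). For compound 4 the estimated value is 1500 nM, with an expected range of 300 nM to 6000 nM.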

Compound 4, half-maximal inhibitory concentration: 6170 nM
For compound 4 the middle estimate is 4.1-fold (0.61 log units) below the measured one, outside the stated range (above it).
By their numbers in this assay, from the lowest: compounds 1, 4, 2 and 3 (each within the scatter of the next, the first and the last beyond it).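

Going by these compounds alone, this is the first direct reading at this position: in this assay, putting hydroxy in place of 2-aminophenyl on the amide-type nitrogen gives a 1.0-fold lower number from compound 2 to compound 4 (0.01 log units; within the scatter) and leaves the two compounds indistinguishable. The group that leaves holds a whole aromatic ring and the group that enters holds a single oxygen, yet for this pair that large difference in size produces no readable difference in the cell result. No supporting measurement is available to explain this match.

From the compounds shown here alone, it remains open how other groups on this nitrogen, such as a methyl or an unsubstituted phenyl, would read in this assay. Within the data shown here, also unsettled is whether the match would hold with 2-chloro-6-fluorophenyl or 2-methoxyphenyl on the far carbonyl carbon, since only one pair tests this exchange.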